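From ethoxy to 3-aminophenoxy on the shared core

The source may hold more compounds than are shown below. What is called first, only, known or untested is meant among the compounds shown, and "the series" means these compounds.

In a functional assay on HMEC-1 cells (Homo sapiens) for antiproliferative activity, read by cell counting, with a stated time of 4 days (a lower number here means a stronger inhibitor, a higher number a weaker inhibitor), compound 3 `CCOc1ccccc1NC(C)=C1C(=O)CC(c2ccccc2)CC1=O` gives 100 nM and lies within the scatter of compound 1 `COc1ccc(Oc2ccccc2NC(C)=C2C(=O)CC(c3ccccc3)CC2=O)cc1OC` at 140 nM in this series, while compound 2 `COc1cc(Oc2ccccc2NC(C)=C2C(=O)CC(c3ccccc3)CC2=O)ccc1N` at 29 nM is the strongest of the three. Compound 4 `CC(Nc1ccccc1Oc1cccc(N)c1)=C1C(=O)CC(c2ccccc2)CC1=O` carries 3-aminophenyl in place of ethyl on an oxygen on an aromatic ring. Within the data shown here, the nearest precedent is a 3.4-fold higher number from compound 2 to compound 3 (0.54 log units; beyond the scatter) when ethyl replaces 4-amino-3-methoxyphenyl, seen here in the opposite sense to the coming change. Without an amino group the same exchange shows only a 1.4-fold lower number from compound 1 to compound 3 (0.15 log units; within the scatter) for ethyl in place of 3,4-dimethoxyphenyl, and amino in place of methoxy gives a 4.8-fold lower number from compound 1 to compound 2 (0.68 log units; beyond the scatter) on the aryl group. The match is incomplete, since compound 4 has no methoxy group. A modest move to a lower number is therefore expected, and the estimated change is a 2.2-fold lower number from compound 3 to compound 4 (0.35 log units; beyond the scatter) in this assay overall. For compound 4 the estimated value is 45 nM as a middle, with an expected range of 15 nM to 130 nM around it.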

Compound 4, half-maximal inhibitory concentration: 41 nM
Estimate against measurement, compound 4: 1.1-fold (0.04 log units) above; the measured number falls inside the stated range.
By their numbers in this assay, from the lowest: compounds 2 and 4 (each within the scatter of the next); then compounds 3 and 1 (each within the scatter of the next).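

In this assay, 3-aminophenyl on this oxygen gives a 2.4-fold lower number from compound 3 to compound 4 (0.39 log units; beyond the scatter), so an aryl group with an amino group and no methoxy group still improves on ethyl. Replacing the larger 4-amino-3-methoxyphenyl with it gives a 1.4-fold higher number from compound 2 to compound 4 (0.15 log units; within the scatter), which is within the scatter, so the methoxy group of compound 2 is not required for a number in this range. Among these compounds, replacing 3,4-dimethoxyphenyl with it gives a 3.4-fold lower number from compound 1 to compound 4 (0.53 log units; beyond the scatter), and across these four compounds both aryl groups bearing an amino group give lower numbers than ethyl and 3,4-dimethoxyphenyl, with no compound going against this.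

No measurement shown explains these differences. On these data alone, it remains open how much depends on the amino group itself rather than the added ring, a question that an unsubstituted phenyl or a dimethylamino group in its place would address.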